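Series notes: a second methoxy group on compound 2

The source may report more compounds than this note shows. Statements on the series, on what has been measured and on what is new or still open speak of the compounds shown alone.

Measured so far in an assay on isolated protein for inhibition of Alpha glucosidase (Homo sapiens), with stated times of 5 min and 15 min, tested at 50 uM; a higher number here means more inhibition at the concentration tested (going by the name of the read-out), a lower number less inhibition:
compound 1 `O=C1/C(=C/c2ccccc2)CCC/C1=C\c1ccc(O)cc1`: 53%
compound 2 `COc1ccc(/C=C2\CCC/C(=C\c3ccccc3)C2=O)cc1`: 31.4%
compound 3 `Cc1ccc(/C=C2\CCC/C(=C\c3ccccc3)C2=O)cc1`: 34.1%

Compound 2 stands lowest of the three numbers. Its nearest neighbour is compound 3, with a number 2.7 percentage points higher from compound 2 to compound 3 (within the scatter), a step within the scatter, so the two cannot be ordered. Its furthest is compound 1, from which a number 21.6 percentage points lower from compound 1 to compound 2 (beyond the scatter), a step beyond the scatter; likewise a number 18.9 percentage points lower from compound 1 to compound 3 (beyond the scatter).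

The next compound is compound 4 `COc1ccc(/C=C2\CCC/C(=C\c3ccccc3)C2=O)c(OC)c1`. Relative to compound 2 the change is methoxy in place of hydrogen on an aromatic carbon. Going by the values given here, no measured step adds a methoxy group where a hydrogen stood: the three steps seen so far all rework the single hydroxy of compound 1, either methylating it, replacing it by methyl, or exchanging methoxy for methyl, and the last of these lay within the scatter. Among the compounds with values here, there is therefore no direct precedent, and the expectation for compound 4 is a step of modest size at most, most likely none beyond the scatter, giving a number 0.6 percentage points higher from compound 2 to compound 4 (within the scatter) in this assay. Compound 4 is estimated at 32%, with a range from 18% to 46%.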

Compound 4, a percentage reported as inhibition, at one concentration (the size of the read-out at that concentration, not a potency): 41%
Compound 4: the middle estimate sits 9 percentage points below what was measured; the measured number falls inside the stated range.
By their numbers in this assay, from the lowest: compounds 2, 3 and 4 (each within the scatter of the next); then compound 1.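

Going by these compounds alone, this is the first measured case of a methoxy group entering where a hydrogen stood, on an aromatic carbon ortho to a large group and meta to a methoxy group, and in this assay the change gives a number 9.6 percentage points higher from compound 2 to compound 4 (within the scatter). Within the data shown here, the ring that already carries the methoxy of compound 2 therefore takes a second methoxy at this place without a step beyond the scatter, so the two compounds cannot be ordered, and the only steps beyond the scatter so far remain those leaving the hydroxy of compound 1. Nothing available bears on why the read-out of compound 4 lies where it does.

Going by these compounds, whether this place stays as undemanding for other groups remains open: an ethoxy group or a longer chain, an amine or a carboxylic acid could each give a step beyond the scatter or none. Also open, on these data alone, is whether a hydroxy group at this place, on its own or alongside the existing methoxy, would produce a step of the size seen on going from compound 1 to its methylated counterpart.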